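Acetyl in place of hydroxyl hydrogen on a purine side chain

The source may report more compounds than this note shows. Statements on the series, on what has been measured and on what is new or still open speak of the compounds shown alone.

Measured compounds: compound 1 `CC(=O)OC(C)n1cnc2c(Cl)nc(I)nc21` with 14100 nM in a functional assay on WI-38 cells (Homo sapiens) for inhibition; on this read-out lower numbers stand for stronger inhibition and higher numbers for weaker inhibition; compound 2 `CC(O)n1cnc2c(N)nc(I)nc21` with > 500000 nM in this assay.

Going by the values given here, compound 1 is the only compound of the two with a number in this assay, where compound 1 gives 14100 nM. For compound 2 the read-out is a limit of this assay, not a number: compound 2 gives > 500000 nM, so compound 2 stands at the limit of > 500000 nM in this assay, at which 1 of the 2 values shown sits. Compound 1 and compound 2 differ in two places, so their values can only be set side by side.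

Compound 3 `CC(=O)OC(C)n1cnc2c(N)nc(I)nc21` is unmeasured. It differs from compound 2 by acetyl in place of hydrogen on an oxygen on a saturated carbon. Among the compounds with values here, no single-change step between measured compounds is known here, so the size of the step is open. Compound 3 is expected to fall to a lower number than compound 2, a step of an at least 3.3-fold lower number from compound 2 to compound 3 (0.52 log units; beyond the scatter), though a limit remains likely. Compound 3 is estimated at 150000 nM, between 20000 nM and 1000000 nM.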

Compound 3, half-maximal inhibitory concentration: > 500000 nM
Compound 3: only a limit was reported; the forecaster's own chance of this, stated with the estimate: 55%; at least 3.3-fold (0.52 log units) between middle value and limit.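

In this assay compound 3 gives > 500000 nM, which is a limit and not a number; compound 2 also stands at a limit, so the step between them cannot be read. With the acetoxy group kept, amino in place of chloro on an aromatic carbon brings an at least 35-fold higher number from compound 1 to compound 3 (1.54 log units; beyond the scatter). Acetyl on this oxygen therefore does not bring the amino compound to a readable number, and only the chloro compound has one: the limit of > 500000 nM in this assay, at which 2 of the 3 values shown sit.

What the acetoxy group contributes when chloro is present stays open, as the hydroxy counterpart of compound 1 is not among the compounds shown. Also open, on these data alone, is how a methylamino or bromo group on that aromatic carbon would read in this assay.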